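Amide swap on compound 3: working notes

The compounds below may be only part of what the source reports. "The series", "measured", "known", "first", "only" and "open" are said of these compounds alone.

In a functional assay on U-937 cells (Homo sapiens) for antiproliferative activity, read by MTT assay, with a stated time of 24 h (a higher number here means a weaker inhibitor, a lower number a stronger inhibitor), compound 1 (`CCCCc1oc2ccccc2c1C(=O)c1ccc(OCC(N)=O)cc1`) gives 42200 nM and compound 2 (`CCCCc1oc2ccccc2c1C(=O)c1ccc(OCC(=O)N2CCCCC2)cc1`) gives 37100 nM. Compound 3 (`CCCCc1oc2ccccc2c1C(=O)c1ccc(OCCCC(=O)N2CCCC2)cc1`) gives 7500 nM, the lowest number of the three, and its gaps to both others lie beyond the scatter.

Compound 4 (`CCCCc1oc2ccccc2c1C(=O)c1ccc(OCCCC(=O)N(C)Cc2ccccc2)cc1`) keeps the saturated chain of compound 3 and changes one group: benzyl(methyl)amino in place of pyrrolidin-1-yl on a carbonyl carbon. This places benzyl(methyl)amino in place of pyrrolidin-1-yl on a carbonyl carbon.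

The closest measured precedent is a 1.1-fold lower number from compound 1 to compound 2 (0.06 log units; within the scatter), also a swap on a carbonyl carbon, and it lies within the scatter. The steps of a 4.9-fold lower number from compound 2 to compound 3 (0.69 log units; beyond the scatter) and a 5.6-fold lower number from compound 1 to compound 3 (0.75 log units; beyond the scatter) are modest, but in each the saturated chain changes together with the group on the carbonyl carbon, so neither isolates a swap of that group. Within the data shown here, no measured pair varies only that group on the chain of compound 3, and no measured compound carries benzyl(methyl)amino, so the uncertainty is wide.

No step beyond the scatter is therefore expected in this assay, in either direction. The expected step is a 1.2-fold lower number from compound 3 to compound 4 (0.06 log units; within the scatter). For compound 4 the estimated value is 6500 nM, with an expected range from 2800 nM to 16000 nM.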

Compound 4, half-maximal inhibitory concentration: 10500 nM
Beside the measured number, compound 4's estimate is 1.6-fold (0.21 log units) below it; measured number inside the range.
By their numbers in this assay, from the lowest: compounds 3 and 4 (each within the scatter of the next); then compounds 2 and 1 (each within the scatter of the next).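

In this assay, the swap on a carbonyl carbon can now be read with the saturated chain of compound 3 held fixed, and a 1.4-fold higher number from compound 3 to compound 4 (0.15 log units; within the scatter) is what that swap gives. Replacing pyrrolidin-1-yl, with its five-membered non-aromatic ring and 5 heavy atoms, by benzyl(methyl)amino, with its six-membered aromatic ring and 9 heavy atoms, therefore does not move the number beyond the scatter on this chain, which agrees with the other swap on a carbonyl carbon, a 1.1-fold lower number from compound 1 to compound 2 (0.06 log units; within the scatter) on the chain of compound 1. Nothing available here bears on why the number holds across this change.

The compounds shown leave open how much of a 4.9-fold lower number from compound 2 to compound 3 (0.69 log units; beyond the scatter) and of a 5.6-fold lower number from compound 1 to compound 3 (0.75 log units; beyond the scatter) belongs to the chain alone, since in both steps the chain and the group on the carbonyl carbon change together. Also open, as far as these compounds go, is whether the chain of compound 3 keeps its number with amino or piperidin-1-yl on the carbonyl carbon, and what a carboxylic acid in place of the amide or a longer chain would give.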